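The source may hold more compounds than are shown below. What is called first, only, known or untested is meant among the compounds shown, and "the series" means these compounds.

Measured compounds:
- compound 1, `Cc1cc(C(=O)NCc2ccccc2)nn1Cc1cc(Cl)ccc1OCc1ccccc1`: 39.8 nM
- compound 2, `Cc1cc(C(=O)NCc2ccncc2)nn1Cc1cc(Cl)ccc1OCc1ccccc1`: 79.4 nM
- compound 3, `Cc1cc(NC(=O)C2CCOCC2)nn1Cc1cc(Cl)ccc1OCc1ccccc1`: 63.1 nM

In an assay on CHO-K1 cells for displacement of a labelled ligand from prostaglandin E2 receptor EP1 subtype (Homo sapiens) (a higher number here means a weaker inhibitor, a lower number a stronger inhibitor), compound 1 gives the lowest of the three numbers, yet both other compounds sit close to it: the step of a 2.0-fold higher number from compound 1 to compound 2 (0.30 log units; within the scatter) and the step of a 1.6-fold higher number from compound 1 to compound 3 (0.20 log units; within the scatter) each stay within the scatter, and so does a 1.3-fold lower number from compound 2 to compound 3 (0.10 log units; within the scatter). Among the compounds with values here, no compound can therefore be called stronger or weaker than another on these numbers.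

Compound 4, `Cc1cc(NC(=O)c2ccccc2)nn1Cc1cc(Cl)ccc1OCc1ccccc1`, has not been measured. It differs from compound 1 in one place: benzamido in place of benzylcarbamoyl on an aromatic carbon. The amide is thus turned around, with the aromatic ring now bound directly to the carbonyl, and the chain is shorter by the count shown.

Within the data shown here, only one measured step bears on this. Compound 3 also carries an amide turned the same way, its nitrogen on the core, and the step of a 1.6-fold higher number from compound 1 to compound 3 (0.20 log units; within the scatter) stayed within the scatter. Among the measured compounds shown here, no measured pair isolates the change from a carbon-linked ring to a ring on the carbonyl alone.

For compound 4 the expected step is a 1.3-fold higher number from compound 1 to compound 4 (0.10 log units; within the scatter), that is, no change beyond the scatter. Compound 4 is therefore estimated at 50 nM, with a range from 20 nM to 125 nM.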

Compound 4, half-maximal inhibitory concentration: 15.9 nM
Beside the measured number, compound 4's estimate is 3.1-fold (0.50 log units) above it; measured number outside the range, below it.
By their numbers in this assay, from the lowest: compound 4; then compounds 1, 3 and 2 (each within the scatter of the next).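

In this assay, this position on the core now shows steps beyond the scatter, as benzamido in place of benzylcarbamoyl gives a modest gain in strength (a 2.5-fold lower number from compound 1 to compound 4 (0.40 log units; beyond the scatter)). The turned amide is not enough on its own, as the group on the carbonyl also counts: phenyl in place of oxan-4-yl gives a larger step (a 4.0-fold lower number from compound 3 to compound 4 (0.60 log units; beyond the scatter)), and the step from the pyridine-bearing amide is the largest of the three (a 5.0-fold lower number from compound 2 to compound 4 (0.70 log units; beyond the scatter)). No measurement at hand explains why these groups differ in this way.

On these data alone, it remains open whether other rings on the carbonyl, such as pyridin-4-yl or cyclohexyl, would match phenyl, and whether a longer chain, as in phenylacetamido, would keep the gain. A methyl group on the amide nitrogen would show whether the amide hydrogen matters.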